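The compounds below may be only part of what the source reports. "The series", "measured", "known", "first", "only" and "open" are said of these compounds alone.

Measured compounds:
compound 1, `CCCCOc1cc(C(C)(C)C)ccc1CNC(=O)C(C)c1ccc(NS(C)(=O)=O)c(F)c1`, 1.4 nM in an assay on cells for antagonist activity at transient receptor potential cation channel subfamily V member 1 (Homo sapiens), read by FLIPR and calcium flux, with a stated time of 6 min; on this read-out lower numbers stand for stronger inhibition and higher numbers for weaker inhibition
compound 2, `CC(C(=O)NCc1ccc(C(C)(C)C)cc1OCc1ccc(F)cc1)c1ccc(NS(C)(=O)=O)c(F)c1`, 3.8 nM in this assay

Compound 2 has the higher of the two numbers; its nearest neighbour is compound 1, and the step of a 2.7-fold higher number from compound 1 to compound 2 (0.43 log units; beyond the scatter) separates them. Compound 3, `CCCCCc1cc(C(C)(C)C)ccc1CNC(=O)C(C)c1ccc(NS(C)(=O)=O)c(F)c1`, is not yet measured. It differs from compound 2 in one place: pentyl in place of (4-fluorobenzyl)oxy on an aromatic carbon.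

Going by the values given here, only one measured step is available for comparison. Going from compound 1 to compound 2 exchanged a plain chain for a ring-bearing group, and the number rose by a 2.7-fold higher number from compound 1 to compound 2 (0.43 log units; beyond the scatter). Among the compounds with values here, the change to compound 3 runs the other way, removing the ring and installing a plain chain, though it also removes the oxygen link, which no measured pair tests. On that basis compound 3 is expected to move back toward compound 1, with a step of a 1.9-fold lower number from compound 2 to compound 3 (0.28 log units; within the scatter) in this assay. Compound 3 is therefore estimated at 2 nM, within a range of 0.6 nM to 8 nM.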

Compound 3, inhibition constant: 2.8 nM
Beside the measured number, compound 3's estimate is 1.4-fold (0.15 log units) below it; measured number inside the range.
By their numbers in this assay, from the lowest: compounds 1, 3 and 2 (each within the scatter of the next, the first and the last beyond it).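

Going by these compounds alone, both earlier compounds carry an oxygen on this aromatic carbon, and compound 3 is the first with none. In this assay, pentyl in place of (4-fluorobenzyl)oxy gives a 1.4-fold lower number from compound 2 to compound 3 (0.13 log units; within the scatter) and pentyl in place of butoxy gives a 2.0-fold higher number from compound 1 to compound 3 (0.30 log units; within the scatter), so neither step stands out from the scatter. Among these three compounds, then, this position carries an oxygen-linked chain, an oxygen-linked ring or a plain carbon chain, and compound 3 still gives 2.8 nM, so neither the oxygen nor the ring is needed for a low nanomolar number here.

No separate data bear on why these numbers sit so close together. On these data alone, how far this tolerance reaches remains open, for instance with a much shorter chain such as methyl, or with an amine or a carboxylic acid on this aromatic carbon.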